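The compounds below may be only part of what the source reports. "The series", "measured", "known", "first", "only" and "open" are said of these compounds alone.

Measured compounds:
compound 1 `O=C(Nc1cccc(-c2oc3cc(-c4ccc(F)cc4)ccc3c(=O)c2O)c1)c1ccc(Cl)cc1`, 4030 nM
compound 2 `COc1ccccc1C(=O)Nc1cccc(-c2oc3cc(-c4ccc(F)cc4)ccc3c(=O)c2O)c1`, 9050 nM
compound 3 `Cc1cc(C(=O)Nc2cccc(-c3oc4cc(-c5ccc(F)cc5)ccc4c(=O)c3O)c2)ccc1F`, 5420 nM

All three share one core and differ only in the aryl group on the amide carbonyl. In a functional assay on HCC1937 cells (Homo sapiens) for antiproliferative activity, read by CCK-8 assay, with a stated time of 72 h (a lower number here means a stronger inhibitor, a higher number a weaker inhibitor), compound 3 gives 5420 nM, the second highest of the three numbers; its nearest neighbour is compound 1 a 1.3-fold higher number from compound 1 to compound 3 (0.13 log units; within the scatter), and the other step that ends at it, a 1.7-fold lower number from compound 2 to compound 3 (0.22 log units; within the scatter), also stays within the scatter, so compound 3 cannot be placed apart from either on these data.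

Compound 4 `COc1cc(OC)cc(C(=O)Nc2cccc(-c3oc4cc(-c5ccc(F)cc5)ccc4c(=O)c3O)c2)c1` is the next member. The change from compound 3 is 3,5-dimethoxyphenyl in place of 4-fluoro-3-methylphenyl on a carbonyl carbon. Of the measured steps, the one that bears most on it is the move to a methoxy-bearing aryl group, a 2.2-fold higher number from compound 1 to compound 2 (0.35 log units; beyond the scatter), which was modest but beyond the scatter in the direction of a weaker inhibitor. The steps involving compound 3 itself, a 1.3-fold higher number from compound 1 to compound 3 (0.13 log units; within the scatter) and a 1.7-fold lower number from compound 2 to compound 3 (0.22 log units; within the scatter), were within the scatter and give no direction of their own. Among the measured compounds shown here, on this basis a modest rise in this assay is expected for compound 4 because a 2.2-fold higher number from compound 1 to compound 2 (0.35 log units; beyond the scatter) is the only step of its kind, though a single step is a thin foundation. The expected step is a 1.6-fold higher number from compound 3 to compound 4 (0.20 log units; within the scatter). Compound 4 is therefore estimated at 8500 nM, with a range from 4000 nM to 18000 nM.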

Compound 4, half-maximal inhibitory concentration: 6250 nM
Compound 4: middle estimate off by 1.4-fold (0.13 log units), on the high side; low and high end bracket the measured number.
By their numbers in this assay, from the lowest: compounds 1, 3, 4 and 2 (each within the scatter of the next, the first and the last beyond it).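

In this assay, the 3,5-dimethoxyphenyl group on this carbonyl carbon cannot be separated from any of the three earlier aryl groups: a 1.2-fold higher number from compound 3 to compound 4 (0.06 log units; within the scatter) and a 1.4-fold lower number from compound 2 to compound 4 (0.16 log units; within the scatter) and also a 1.6-fold higher number from compound 1 to compound 4 (0.19 log units; within the scatter) all stay within the scatter. The earlier gap between the 4-chlorophenyl and 2-methoxyphenyl groups, a 2.2-fold higher number from compound 1 to compound 2 (0.35 log units; beyond the scatter) in the same assay, therefore does not extend to every aryl group bearing methoxy, since compound 4 carries such a group and still cannot be told apart from compound 1. Replacing 4-fluoro-3-methylphenyl, which has no hydrogen-bond acceptors, with a group that has them also leaves no readable shift, and nothing measured here explains why these aryl groups give such similar numbers.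

The compounds shown leave open whether an aryl group carrying an amine or a carboxylic acid, or a longer alkyl chain in place of the aryl group, would move the number beyond the scatter seen in this set. They also leave open whether removing the hydroxyl group from the shared core would matter more than any change on the carbonyl carbon.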